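The source may report more compounds than this note shows. Statements on the series, on what has been measured and on what is new or still open speak of the compounds shown alone.

Measured in an ADME assay on microsomes from liver (Homo sapiens) for metabolic stability; on this read-out lower numbers stand for a shorter-lived compound and higher numbers for a longer-lived compound:
- Compound 1 `CC(C)[C@H](C[C@H]1CCNC1=O)c1ccc(-c2ccc3cccc(F)c3c2)[nH]c1=O`: 0.257 h
- Compound 2 `CC(C)C(Cc1nnn[nH]1)c1ccc(-c2ccc3cccc(F)c3c2)[nH]c1=O`: > 3 h
- Compound 3 `CC(C)C(c1ccc(-c2ccc3cccc(F)c3c2)[nH]c1=O)N1CCNC1=O`: 1.03 h

Compound 1 gives 0.257 h, the lowest number shown, while compound 3 gives 1.03 h. For compound 2, > 3 h is a limit and not a number.

Compound 4 `CC(C)[C@@H](C[C@H]1CCNC1=O)c1ccc(-c2ccc3cccc(F)c3c2)[nH]c1=O` is the counterpart of compound 1: the two compounds have the same atoms and bonds and differ only in configuration as drawn: 1 of 2 stereo elements differ; a stereocentre at a saturated chain carbon is drawn S in compound 1 and R in compound 4. Among the compounds with values here, the only measured step, an at least 2.9-fold lower number from compound 2 to compound 3 (0.46 log units; beyond the scatter), exchanges one group for another and leaves configuration aside, so it bears only loosely on this change. Within the data shown here, no measured pair isolates a change of configuration. The expectation therefore rests on compound 1 at 0.257 h, and no step beyond the scatter is expected in this assay, in either direction. The estimated step is a 1.2-fold higher number from compound 1 to compound 4 (0.07 log units; within the scatter). Compound 4 is expected at 0.3 h, with an estimated range of 0.13 h to 0.7 h.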

Compound 4, half-life in the Homo sapiens assay: 0.693 h
Compound 4: the middle estimate sits 2.3-fold (0.36 log units) below what was measured, and the stated range covers the measured number.
By their numbers in the Homo sapiens assay, from the lowest: compound 1; then compounds 4 and 3 (each within the scatter of the next). At a limit, above all of these: compound 2.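

In the Homo sapiens assay, the change of configuration gives a 2.7-fold higher number from compound 1 to compound 4 (0.43 log units; beyond the scatter), which brings compound 4 to 0.693 h, the first measured sign that the drawn S or R at this saturated chain carbon matters. This step can be assigned to that stereocentre alone because of one fact: the fact that compounds 1 and 4 differ only in the configuration as drawn. In a physicochemical assay for solubility, measured as kinetic solubility, at pH 2 (on this read-out lower numbers stand for lower solubility and higher numbers for higher solubility), compound 1 gives 38300 nM and compound 4 gives 25400 nM. In the physicochemical assay, the same change gives a 1.5-fold lower number from compound 1 to compound 4 (0.18 log units; within the scatter), so no shift beyond the scatter appears on that read-out.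

The compounds shown leave open whether the second stereo element, drawn alike in compound 1 and compound 4, matters too. They also leave open how a carboxylic acid or an amine on this chain would read in the Homo sapiens assay.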